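Swapping a Pyridine Ring for an Imidazole Ring

The source may report more compounds than this note shows. Statements on the series, on what has been measured and on what is new or still open speak of the compounds shown alone.

Among the compounds with values here, in a functional assay on CWR22R cells (Homo sapiens) for antiproliferative activity, read by CCK-8 assay, with a stated time of 6 days (a higher number here means a weaker inhibitor, a lower number a stronger inhibitor), compound 1 `CCN(c1ccc(C#N)c(Cl)c1)c1cc(-c2ccncc2)ccc1C` gives 1030 nM, the lowest of the two numbers known so far. Compound 2 `N#Cc1ccc(N2CCc3cc(-c4cnc5ccccc5c4)ccc3C2)cc1C(F)(F)F`, built on a different core, gives 25900 nM in this assay, a far higher number that lies beyond the scatter. Compound 3 `CCN(c1ccc(C#N)c(Cl)c1)c1cc(-n2ccnc2)ccc1C` keeps the core of compound 1 with one change: 1H-imidazol-1-yl in place of pyridin-4-yl on an aromatic carbon. Within the data shown here, no measured pair shows a change of this kind, so its effect is uncertain. Without such a pair, a modest step of a 1.9-fold higher number from compound 1 to compound 3 (0.29 log units; within the scatter) is expected, most likely toward a weaker inhibitor. Compound 3 is therefore estimated at 2000 nM, within a range of 600 nM to 7000 nM.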

Compound 3, half-maximal inhibitory concentration: > 30000 nM
Compound 3: only a limit was reported; the forecaster's own chance of this, stated with the estimate: 5%; middle value at least 15-fold (1.17 log units) from the limit.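

In this assay the change from pyridin-4-yl to 1H-imidazol-1-yl brings an at least 29-fold higher number from compound 1 to compound 3 (1.46 log units; beyond the scatter) and shows that this place, para to a methyl group, does not accept every small aromatic ring alike. Compound 3 gives > 30000 nM as a limit of the assay and not a number. The true size of the step therefore stays unknown: the limit of > 30000 nM in this assay, at which 1 of the 3 values shown sits.

From the compounds shown here alone, whether the ring size, the second ring nitrogen or the point of attachment matters most remains open. A phenyl ring, pyridin-3-yl or an amine at this place would help separate these possibilities.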